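Chloro substitution on the benzoyl ring of compound 2

This account rests on a few compounds, and the source may have more. Where it says the series, first, only, none or still open, it means among the compounds named here.

For the measured compounds named here, compound 2 `COc1cccc(-c2csc(N)c2C(=O)c2ccccc2)c1` gives 34% in a functional assay on CHO cells for agonist activity at adenosine receptor A1 (Homo sapiens), read by fluorescence and ERK phosphorylation, with stated times of 30 min and 1.5 h, tested at 10 uM (a lower number here means a weaker effect, a higher number a stronger effect of the compound at the concentration tested), the lowest of the two numbers measured so far. Compound 1 `Nc1scc(-c2cccc(F)c2)c1C(=O)c1ccccc1` gives 52%, and the step of a number 18 percentage points lower from compound 1 to compound 2 (beyond the scatter), methoxy in place of fluoro on an aromatic carbon, lies beyond the scatter. Compound 3 `COc1cccc(-c2csc(N)c2C(=O)c2ccc(Cl)cc2)c1` differs from compound 2 by chloro in place of hydrogen on an aromatic carbon. Going by the values given here, no measured step touches this aromatic carbon; the single known step concerns the other ring and offers no guide for this assay here. For compound 3 a step of a number 1 percentage points higher from compound 2 to compound 3 (within the scatter) is expected, within the scatter. The estimate for compound 3 is 35% with a range of 15% to 55%.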

Compound 3, a percentage reported as activity, at one concentration (the size of the read-out at that concentration, not a potency): 60%
For compound 3 the middle estimate is 25 percentage points below the measured one; measured number outside the range, above it.
By their numbers in this assay, from the lowest: compound 2; then compounds 1 and 3 (each within the scatter of the next).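

Phenyl to 4-chlorophenyl is the first change shown on this ring, and in this assay it gives a number 26 percentage points higher from compound 2 to compound 3 (beyond the scatter), so the read-out responds to a substituent at this place, para to a large group, at least with methoxy on the other ring. No available evidence accounts for the rise.

From the compounds shown here alone, whether a methyl group or an amine at the same place would give a similar step stays open. So does whether the chloro step carries over when fluoro stands in place of methoxy.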